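A piperidinylcarbonyl group in place of the side group of compound 2

The source may hold more compounds than are shown below. What is called first, only, known or untested is meant among the compounds shown, and "the series" means these compounds.

Compound 2 `COc1ccc(-c2nc(/N=C(\N)NC(C)C)sc2-c2ccc(OC)cc2)cc1` has the highest number of the three measured compounds: in a functional assay (aorta) with Rattus norvegicus as the target (on this read-out higher numbers stand for an effect only at larger amounts of compound and lower numbers for an effect already at smaller amounts), compound 2 gives 9.1 uM. Compound 1 `CNC(=N)Nc1nc(-c2ccc(OC)cc2)c(-c2ccc(OC)cc2)s1` gives 1.2 uM, and compound 3 `C/N=C(/NC)Nc1nc(-c2ccc(OC)cc2)c(-c2ccc(OC)cc2)s1` gives 2.4 uM. The step of a 7.6-fold higher number from compound 1 to compound 2 (0.88 log units; beyond the scatter) and the step of a 3.8-fold lower number from compound 2 to compound 3 (0.58 log units; beyond the scatter) both lie beyond the scatter, while the step of a 2.0-fold higher number from compound 1 to compound 3 (0.30 log units; within the scatter) does not. Compound 4 `COc1ccc(-c2nc(C(=O)N3CCCCC3)sc2-c2ccc(OC)cc2)cc1` differs from compound 2 by a group of 8 heavy atoms (6 carbon, 1 nitrogen, 1 oxygen; one six-membered non-aromatic ring with 1 hetero atom) in place of a group of 7 heavy atoms (4 carbon, 3 nitrogen; no ring), on an aromatic carbon. The two steps that alter the group on that same aromatic carbon were modest, so a modest step in this assay is expected, but every measured compound carries the leaving group, so the direction is uncertain; the step of a 1.6-fold higher number from compound 2 to compound 4 (0.22 log units; within the scatter) is the estimate. Compound 4 is expected to give 15 uM, within 3 uM to 60 uM.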

Compound 4, concentration for half-maximal effect: 11 uM
For compound 4 the middle estimate is 1.4-fold (0.13 log units) above the measured one, and the stated range covers the measured number.
By their numbers in this assay, from the lowest: compounds 1 and 3 (each within the scatter of the next); then compounds 2 and 4 (each within the scatter of the next).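

Compound 4 is the only one shown with a ring-bearing group, (piperidin-1-yl)carbonyl, on this aromatic carbon, and in this assay replacing the open-chain group of compound 2 gives a 1.2-fold higher number from compound 2 to compound 4 (0.08 log units; within the scatter), so hydrogen-bond donors on this group are not required to stay at the level of compound 2. Against the groups of the other two compounds, the same kind of exchange gives a 4.6-fold higher number from compound 3 to compound 4 (0.66 log units; beyond the scatter) and a 9.2-fold higher number from compound 1 to compound 4 (0.96 log units; beyond the scatter), so neither compound 2 nor compound 4 reaches their lower numbers. No evidence shown accounts for these steps. Open, from the compounds shown here alone, is how a morpholine-4-carbonyl group or a plain amine on this carbon would compare.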